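The compounds below may be only part of what the source reports. "The series", "measured", "known", "first", "only" and "open" are said of these compounds alone.

Compound 1 `Cc1ccc(-c2cnn3c(NCc4ccccn4)cc(C)nc23)cc1` was tested in a physicochemical assay for solubility, read by HPLC, using the shake flask method, measured as kinetic solubility, with a stated time of 2 h, at pH 7.4 (on this read-out lower numbers stand for lower solubility and higher numbers for higher solubility), and there compound 1 gives < 5000 nM, which is a limit of the assay rather than a number; among the three values shown, (the limit of < 5000 nM in this assay, at which 1 of the 3 values shown sits). Two further compounds share the core of compound 1: compound 2 `Cc1cc(NCc2ccncc2)n2nc(C)c(-c3ccccc3)c2n1` gives 134000 nM, and compound 3 `Cc1cc(NCc2ccccn2)n2nc(C)c(Nc3ccccc3)c2n1` gives 7800 nM. Compound 4 `Cc1cc(NCc2ccccn2)n2ncc(-c3cncnc3)c2n1` has not yet been measured. It differs from compound 1 in one place: pyrimidin-5-yl in place of 4-methylphenyl on an aromatic carbon. For the measured compounds named here, no step between measured compounds shows how such a change moves solubility, so the size of this step rests on expectation alone. Compound 4 is expected to be more soluble, by an estimated at least 6.0-fold higher number from compound 1 to compound 4 (0.77 log units; beyond the scatter). Compound 4 is expected to reach about 30000 nM, within a range from 8000 nM to 120000 nM.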

Compound 4, solubility: 111000 nM
Beside the measured number, compound 4's estimate is 3.7-fold (0.57 log units) below it, within the range that was stated.
By their numbers in this assay, from the lowest: compound 3; then compounds 4 and 2 (each within the scatter of the next). At a limit, below all of these: compound 1.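

In this assay, pyrimidin-5-yl in place of 4-methylphenyl on an aromatic carbon gives an at least 22-fold higher number from compound 1 to compound 4 (1.34 log units; beyond the scatter). The earlier compounds shown here offered no readable step at this position, and this one shows that the read-out can move by a large margin with a change of ring here. The true size of the step stays unknown, as the value for compound 1 is a limit of the assay and not a number: the limit of < 5000 nM in this assay, at which 1 of the 4 values shown sits.

Still open, as far as these compounds go, is how much of the step belongs to the nitrogens of the pyrimidin-5-yl ring and how much to the loss of the methyl. A pyridin-3-yl group at this place could help to separate the two.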